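This account rests on a few compounds, and the source may have more. Where it says the series, first, only, none or still open, it means among the compounds named here.

Measured so far in a functional assay on PC-12 cells (Rattus norvegicus) for cytotoxicity, read by MTT assay, with stated times of 2 h and 24 h, tested at 10 uM; a lower number here means a weaker effect, a higher number a stronger effect of the compound at the concentration tested:
Compound 1, `Cc1ccc(-n2nc(-c3ccc(C(F)(F)F)cc3O)nc2-c2ccccc2O)cc1`, gives 102%.
Compound 2, `Oc1cc(C(F)(F)F)ccc1-c1nc(-c2ccccc2O)n(-c2ccccc2F)n1`, gives 100%.

Compound 2 has only compound 1 beside it on these numbers, and the step of a number 2 percentage points lower from compound 1 to compound 2 (within the scatter) lies within the scatter, so the two values are not told apart; both sit at full effect at the concentration tested.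

Compound 3, `Cc1ccc(-n2nc(-c3ccc(C(F)(F)F)cc3O)nc2-c2ccccc2O)c(C)c1`, is not yet measured. It differs from compound 2 by 2,4-dimethylphenyl in place of 2-fluorophenyl on an aromatic nitrogen. Among the measured compounds shown here, the one measured step that bears on this is the exchange of a group on the same aromatic nitrogen, a number 2 percentage points lower from compound 1 to compound 2 (within the scatter), which did not move the read-out beyond the scatter. For the measured compounds named here, no other step touches this part of the molecule. The change to compound 3 is therefore expected to give a step of a number 1 percentage points higher from compound 2 to compound 3 (within the scatter) in this assay, none beyond the scatter. Compound 3 is estimated at 101% in this assay, within a range from 90% to 112%.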

Compound 3, a percentage reported as activity, at one concentration (the size of the read-out at that concentration, not a potency): 106%
Compound 3: the middle estimate sits 5 percentage points below what was measured, within the range that was stated.
By their numbers in this assay, from the lowest: compounds 2, 1 and 3 (each within the scatter of the next).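

In this assay, the aromatic nitrogen now carries a third group: 2,4-dimethylphenyl in place of 2-fluorophenyl gives a step of a number 6 percentage points higher from compound 2 to compound 3 (within the scatter) and so does not separate these two groups on this read-out. The cleaner comparison, methyl in place of hydrogen on an aromatic carbon of the group on that nitrogen, gives a step of a number 4 percentage points higher from compound 1 to compound 3 (within the scatter) and shows that this added methyl is also tolerated without a resolved change at the concentration tested. No evidence is available to explain the unchanged read-out across these three compounds.

As far as these compounds go, all three groups on this nitrogen are substituted phenyl rings, so a carboxylic acid on that ring, an amine or a longer alkyl chain in place of the ring remains open. From the compounds shown here alone, the trifluoromethyl and hydroxyl groups are shared by all three compounds, so what they contribute also remains open.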